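This account rests on a few compounds, and the source may have more. Where it says the series, first, only, none or still open, it means among the compounds named here.

Two compounds of the series carry numbers in an assay on HEK293 cells for binding affinity to Neuropeptide Y receptor type 5 (Homo sapiens), read by radioligand binding (on this read-out lower numbers stand for stronger inhibition and higher numbers for weaker inhibition), so far. Compound 1, `COc1ccc(S(=O)(=O)Nc2ccc(-c3cc(N)n(-c4cccc(C)c4)n3)cc2)cc1`, gives 37 nM. Compound 2, `Nc1cc(C2CCC(CNS(=O)(=O)c3ccccc3[N+](=O)[O-])CC2)nn1-c1ccc(C(F)(F)F)cc1`, gives 10 nM, the lower of the two numbers; the gap to compound 1 lies beyond the usual scatter. Compound 3, `Nc1ccccc1S(=O)(=O)NCC1CCC(c2cc(N)n(-c3ccc(C(F)(F)F)cc3)n2)CC1`, departs from compound 2 in one place: amino in place of nitro on an aromatic carbon. Among the compounds with values here, no measured pair shows this change, so its size rests on judgement alone; a small shift, not beyond the scatter, is expected, with the expected step given by a 1.5-fold higher number from compound 2 to compound 3 (0.18 log units; within the scatter). Compound 3 is accordingly estimated near 15 nM, within a range from 5 nM to 45 nM.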

Compound 3, half-maximal inhibitory concentration: 20 nM
Compound 3: middle estimate off by 1.3-fold (0.12 log units), on the low side; the range from low to high includes it.
By their numbers in this assay, from the lowest: compounds 2, 3 and 1 (each within the scatter of the next, the first and the last beyond it).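

The exchange of 2-nitrophenyl for 2-aminophenyl, on an aromatic carbon ortho to a large group, gives a 2.0-fold higher number from compound 2 to compound 3 (0.30 log units; within the scatter) in this assay. This single pair shows that nitro and amino can be exchanged at this place without a step beyond the scatter, although amino brings a hydrogen-bond donor that nitro lacks. No supporting measurement bears on this result.

Still open, going by these compounds, is how a carboxylic acid, a methylamino group or a fluorine would read at this place. Also open, on these data alone, is whether the same exchange reads alike with the trifluoromethyl group replaced.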